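The compounds below may be only part of what the source reports. "The series", "measured", "known", "first", "only" and "open" are said of these compounds alone.

In a functional assay on PC-3 cells (Homo sapiens) for antiproliferative activity, read by WST assay, with a stated time of 3 days (a higher number here means a weaker inhibitor, a lower number a stronger inhibitor), compound 1 (`CCOc1c(-c2cc(OC)c(OC)c(OC)c2)oc2ccccc2c1=O`) gives 900 nM while compound 2 (`CCCOc1c(-c2cc(OC)c(OC)c(OC)c2)oc2ccccc2c1=O`) gives 11800 nM and compound 3 (`COc1cc(-c2oc3ccccc3c(=O)c2OC(C)C)cc(OC)c1OC`) gives 21200 nM on this scale. Compound 3 therefore sits with compound 2 at the weak end of the three, and the gap between them is a 1.8-fold higher number from compound 2 to compound 3 (0.25 log units; within the scatter) here. Compound 4 (`CCN(CC)CCCOc1c(-c2cc(OC)c(OC)c(OC)c2)oc2ccccc2c1=O`) carries 3-(diethylamino)propyl in place of isopropyl on an oxygen on an aromatic ring. The closest evidence is a 13-fold higher number from compound 1 to compound 2 (1.12 log units; beyond the scatter) and a 24-fold higher number from compound 1 to compound 3 (1.37 log units; beyond the scatter) (both large and upward), yet neither step adds a nitrogen, so they guide this change only weakly. With compound 3 already at the weak end, the expected step is moderate and downward (a 4.2-fold lower number from compound 3 to compound 4 (0.63 log units; beyond the scatter)) with wide uncertainty. For compound 4 the estimated value is 5000 nM with an expected range (1000 nM to 20000 nM).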

Compound 4, half-maximal inhibitory concentration: 13600 nM
Compound 4: middle estimate off by 2.7-fold (0.43 log units), on the low side, and the stated range covers the measured number.
By their numbers in this assay, from the lowest: compound 1; then compounds 2, 4 and 3 (each within the scatter of the next).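

In this assay, the long 3-(diethylamino)propyl group on this oxygen reads the same as isopropyl within the scatter (a 1.6-fold lower number from compound 3 to compound 4 (0.19 log units; within the scatter)), and adding diethylamino to the end of the propyl chain also changes nothing beyond the scatter (a 1.2-fold higher number from compound 2 to compound 4 (0.06 log units; within the scatter)). The added nitrogen therefore brings back none of the ground lost against the ethyl group of compound 1 (a 15-fold higher number from compound 1 to compound 4 (1.18 log units; beyond the scatter)). Nothing measured here gives a reason for this. The compounds shown leave open whether a methyl group or a shorter 2-(diethylamino)ethyl chain on this oxygen would come closer to compound 1.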